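From 3-chlorophenyl to 2-methylphenyl in compound 4

The source may report more compounds than this note shows. Statements on the series, on what has been measured and on what is new or still open speak of the compounds shown alone.

In an ADME assay (liver) for metabolic stability, with Liver microsome (Rattus norvegicus) as the target, read by LC-MS, using microsomes, with a stated time of 30 min, tested at 4 uM (a lower number here means that less of the compound is left, a higher number that more of the compound is left), compound 1 `COCCn1c(-c2ccccc2Cl)nc2c(N3CCN(C(C)=O)CC3)nc(C)nc21` gives 95% and compound 2 `COCCn1c(-c2ccccc2Cl)nc2c(N3CCN4C(=O)CCC4C3)nc(C)nc21` gives 91%. Compound 3 `Cc1nc(N2CCN(C)CC2)c2nc(-c3cccc(Cl)c3)n(C3CCOCC3)c2n1` stands lowest of the three at 45%, beyond the scatter of both others. Compound 4 `Cc1nc(N2CCN(C)CC2)c2nc(-c3ccccc3C)n(C3CCOCC3)c2n1` differs from compound 3 in one group only: 2-methylphenyl in place of 3-chlorophenyl on an aromatic carbon. That group sits on an aromatic carbon of a five-membered aromatic ring with 2 nitrogen, next to the ring atom that bears an oxan-4-yl group.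

For the measured compounds named here, the only step measured between closely matched compounds is a number 4 percentage points lower from compound 1 to compound 2 (within the scatter), and it lies at a different place, so it says little about this exchange. Compounds 1 and 2 differ from compound 3 in several places, so their values cannot be credited to any single group. Going by the values given here, with no measured step at this place, the expectation rests on compound 3 at 45%, and no step beyond the scatter is expected in this assay. The expected change is a number 2 percentage points lower from compound 3 to compound 4 (within the scatter). Compound 4 is estimated at 43%, with an expected range from 22% to 65%.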

Compound 4, percent of the compound remaining: 39%
For compound 4 the middle estimate is 4 percentage points above the measured one, within the range that was stated.
By their numbers in this assay, from the lowest: compounds 4 and 3 (each within the scatter of the next); then compounds 2 and 1 (each within the scatter of the next).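

In this assay, the first exchange seen at this place, on an aromatic carbon of a five-membered aromatic ring with 2 nitrogen, gives a number 6 percentage points lower from compound 3 to compound 4 (within the scatter). With oxan-4-yl and the rest of the structure unchanged, 2-methylphenyl can thus stand in place of 3-chlorophenyl without a step beyond the scatter in this read-out. The exchange alters both the kind of substituent on the phenyl ring and where it sits, and no measurement here explains the outcome or separates those two changes.

On these data alone, it remains open whether a ring of another kind at this place, such as a pyridine or a cyclohexyl ring, would give a similar number. As far as these compounds go, it is also open whether the same exchange would behave alike with a group other than oxan-4-yl on the ring nitrogen.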